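Propoxy in Place of Ethyl: Expectation for Compound 4

The source may hold more compounds than are shown below. What is called first, only, known or untested is meant among the compounds shown, and "the series" means these compounds.

Compound 1, `O=C(Nc1ccc(Cl)cc1)NS(=O)(=O)c1cccs1`: 16% in a functional assay on the whole organism (6C3HED cells, Mus musculus) for inhibition, at a dose of 150 mg/kg by the oral route; on this read-out higher numbers stand for more inhibition at the one dose given (going by the name of the read-out) and lower numbers for less inhibition
Compound 2, `COc1ccc(S(=O)(=O)NC(=O)Nc2ccc(Cl)cc2)s1`: 93%
Compound 3, `CCc1ccc(S(=O)(=O)NC(=O)Nc2ccc(Cl)cc2)s1`: 57%

Among the three measured compounds, compound 3 stands second highest: a number 41 percentage points higher from compound 1 to compound 3 (beyond the scatter), while a number 36 percentage points lower from compound 2 to compound 3 (beyond the scatter). Compound 4, `CCCOc1ccc(S(=O)(=O)NC(=O)Nc2ccc(Cl)cc2)s1`, differs from compound 3 in one place: propoxy in place of ethyl on an aromatic carbon. For the measured compounds named here, two steps bear on this change. a number 77 percentage points higher from compound 1 to compound 2 (beyond the scatter), and a number 36 percentage points lower from compound 2 to compound 3 (beyond the scatter); the entering group shares one oxygen with methoxy, but no compound with propoxy has been measured, so the size is uncertain. A rise beyond the scatter is expected for compound 4, a number 15 percentage points higher from compound 3 to compound 4 (beyond the scatter). Compound 4 is therefore estimated at 72%, within a range from 45% to 95%.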

Compound 4, a percentage reported as inhibition, in the whole organism at one dose (the size of the read-out at that dose, not a potency): 44%
Estimate against measurement, compound 4: 28 percentage points above, and the stated range ends above it.
By their numbers in this assay, from the lowest: compound 1; then compound 4; then compound 3; then compound 2.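

In this assay the move from methoxy to propoxy is costly, with a number 49 percentage points lower from compound 2 to compound 4 (beyond the scatter) for ethyl added on the saturated chain carbon bound to the oxygen. An oxygen at this place therefore does not by itself carry a high number, as a number 13 percentage points lower from compound 3 to compound 4 (beyond the scatter) shows for propoxy in place of ethyl, although a number 28 percentage points higher from compound 1 to compound 4 (beyond the scatter) still stands as a gain over hydrogen. As far as these compounds go, whether ethoxy or an amine at this place would match methoxy stays open. Nothing shown explains the fall with the longer chain.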